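Trifluoromethoxy for Trifluoromethyl on a Weak Inhibitor

The source may hold more compounds than are shown below. What is called first, only, known or untested is meant among the compounds shown, and "the series" means these compounds.

Compound 1 `Oc1ccc(-c2cc(-c3ccccc3C(F)(F)F)cc(-c3ccccc3O)n2)cc1` gives 6690 nM in a functional assay on DU-145 cells (Homo sapiens) for inhibition; a lower number here means a stronger inhibitor, a higher number a weaker inhibitor. Compound 2 `Oc1ccc(-c2cc(-c3ccccc3C(F)(F)F)cc(-c3ccc(O)cc3)n2)cc1` carries a 4-hydroxyphenyl in place of the 2-hydroxyphenyl, and in this assay compound 2 reaches only the limit > 50000 nM. The step of an at least 7.4-fold higher number from compound 1 to compound 2 (0.87 log units; beyond the scatter) therefore rests on (the limit of > 50000 nM in this assay, at which 1 of the 2 values shown sits), so compound 2 stands at the weak end of what the assay can report. Compound 3 `Oc1ccc(-c2cc(-c3ccccc3OC(F)(F)F)cc(-c3ccc(O)cc3)n2)cc1` differs from compound 2 by trifluoromethoxy in place of trifluoromethyl on an aromatic carbon. For the measured compounds named here, no measured step in this set touches that change; the only step measured, from compound 1 to compound 2, concerns the hydroxyphenyl and says nothing about the trifluoromethyl. No shift beyond the scatter is therefore expected in this assay, and compound 3 is expected to remain near the limit. For compound 3 the estimate is 70000 nM, between 20000 nM and 250000 nM. The expected step that the limit leaves unreadable from compound 2 to compound 3 is thus essentially flat.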

Compound 3, half-maximal inhibitory concentration: 16000 nM
The estimate for compound 3 lay 4.4-fold (0.64 log units) above the measured number; measured number outside the range, below it.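

In this assay, trifluoromethoxy in place of trifluoromethyl, on an aromatic carbon ortho to a large group, gives an at least 3.1-fold lower number from compound 2 to compound 3 (0.49 log units; beyond the scatter). This position, which the earlier step did not touch, therefore responds to the group it carries, and compound 3 shows that two 4-hydroxyphenyl groups do not by themselves leave a compound at the limit of the assay. The size of the step is only a lower bound, as the value of compound 2 is a limit and not a number: the limit of > 50000 nM in this assay, at which 1 of the 3 values shown sits.

From the compounds shown here alone, whether the response follows the oxygen that enters or the group as a whole stays open, and a methoxy or a chlorine at this position would bear on that. Also open, going by these compounds, is whether trifluoromethoxy would shift the number in the same direction alongside the 2-hydroxyphenyl of compound 1.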